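The source may report more compounds than this note shows. Statements on the series, on what has been measured and on what is new or still open speak of the compounds shown alone.

Measured in a functional assay on the whole organism for inhibition, with Brassica rapa subsp. chinensis as the target, with a stated time of 3 days, tested at 100 ppm; a lower number here means less inhibition of growth, a higher number more inhibition of growth at the concentration tested:
compound 1 `CCCCCNC(=O)/C=C/c1ccccc1`: 76%
compound 2 `CCCCCCCCCCNC(=O)/C=C/c1ccccc1`: 15%
compound 3 `CCCCCCCCNC(=O)/C=C/c1ccccc1`: 42%

Among these three, compound 1 stands highest, and compounds 2 and 3 carry longer saturated chains on the same core. Compound 4 `C=CCNC(=O)/C=C/c1ccccc1` has not yet been measured. Its change from compound 1 is vinyl in place of butyl on a saturated chain carbon bound to an amide-type nitrogen, which reads as vinyl in place of butyl on a saturated chain carbon bound to an amide-type nitrogen, or pentyl to allyl when cut one bond further out.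

The measured steps that bear on this all concern chain length: a number 34 percentage points lower from compound 1 to compound 3 (beyond the scatter), a number 61 percentage points lower from compound 1 to compound 2 (beyond the scatter) and a number 27 percentage points higher from compound 2 to compound 3 (beyond the scatter). All three lie beyond the scatter, and in these three compounds the shorter chain gives the higher number. Going by these compounds, none of them, however, goes shorter than pentyl or introduces a double bond in the chain, so the direction for compound 4 remains open. With compound 1 at 76% as the top of the series, a moderate fall is expected rather than a further rise. The expected change is a number 16 percentage points lower from compound 1 to compound 4 (beyond the scatter). Compound 4 is estimated at 60%, within an expected range of 35% to 85%.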

Compound 4, percent growth inhibition at one concentration: 64%
Compound 4: the middle estimate sits 4 percentage points below what was measured; the range from low to high includes it.
By their numbers in this assay, from the lowest: compound 2; then compound 3; then compound 4; then compound 1.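

In this assay, exchanging the pentyl chain of compound 1 for the shorter allyl chain gives a number 12 percentage points lower from compound 1 to compound 4 (beyond the scatter), so this change at the chain bound to the amide-type nitrogen also falls short of compound 1. The longer chains lie further down, with a number 34 percentage points lower from compound 1 to compound 3 (beyond the scatter) and a number 61 percentage points lower from compound 1 to compound 2 (beyond the scatter), which leaves compound 1 the highest of the four and shows that the number falls on both the shorter and the longer side of pentyl among these chains. No measurement offered here explains why the allyl compound gives a lower number than the pentyl compound.

The step shortens the chain and brings in a double bond together, and the compounds shown do not separate these two changes. A saturated propyl chain would bear on that question, and a hexyl chain on how the number behaves just beyond pentyl.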